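The compounds below may be only part of what the source reports. "The series", "measured", "known", "first", "only" and "open" are said of these compounds alone.

Measured compounds:
- Compound 1 `O=C(c1cccnc1)N1CCN(c2ncccn2)CC1`: 74%
- Compound 2 `O=C(c1ccc[n+](Cc2ccccc2)c1)N1CCN(c2ccccc2Cl)CC1`: 89%
- Compound 3 `O=C(c1ccc[n+](Cc2ccccc2F)c1)N1CCN(c2ccccc2Cl)CC1`: 85%

In a functional assay on a cell-free system (Platelet, plasma, Homo sapiens), with stated times of 4 min and 5.5 min, tested at 1 uM (on this read-out higher numbers stand for a weaker effect at the one concentration tested and lower numbers for a stronger effect), compound 3 gives 85%, the second highest of the three numbers. Its nearest neighbour is compound 2 with 89%, within the scatter of compound 3, and the furthest is compound 1 with 74%, lower by more than the scatter.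

Compound 4 `O=C(c1ccc[n+](Cc2ccc(Br)cc2)c1)N1CCN(c2ccccc2Cl)CC1` differs from compound 3 in one place: 4-bromophenyl in place of 2-fluorophenyl on a saturated chain carbon bound to an aromatic nitrogen. Within the data shown here, the only measured step that touches the benzyl group is a number 4 percentage points lower from compound 2 to compound 3 (within the scatter), which did not move the read-out beyond the scatter. Among the measured compounds shown here, no measured step swaps one halogen for another on that ring.

On this basis compound 4 is expected to sit close to compound 3, with a step of no change at the digits printed from compound 3 to compound 4 (within the scatter) in this assay. The estimate for compound 4 is 85%, between 72% and 96%.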

Compound 4, a percentage reported as activity, at one concentration (the size of the read-out at that concentration, not a potency): 69%
Beside the measured number, compound 4's estimate is 16 percentage points above it, outside the stated range (below it).
By their numbers in this assay, from the lowest: compounds 4 and 1 (each within the scatter of the next); then compounds 3 and 2 (each within the scatter of the next).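

In this assay, a change on the benzyl ring now moves the read-out beyond the scatter, towards a stronger effect: bromo in place of hydrogen gives a number 20 percentage points lower from compound 2 to compound 4 (beyond the scatter), and 4-bromophenyl in place of 2-fluorophenyl gives a number 16 percentage points lower from compound 3 to compound 4 (beyond the scatter). This position is therefore not indifferent to what the ring carries, which the fluoro step alone did not reveal. Nothing available explains the shift.

Compound 3 and compound 4 differ in both the halogen and its place on the ring, so the two effects cannot be separated. Going by these compounds, how a chloro or methoxy group on that ring, or a longer chain in place of the benzyl, would behave stays open.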